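Methoxy in Place of Methyl on the Chain

The source may hold more compounds than are shown below. What is called first, only, known or untested is meant among the compounds shown, and "the series" means these compounds.

Measured so far in a functional assay on ileum for inhibition of histamine H1 receptor (Cavia porcellus); a lower number here means a stronger inhibitor, a higher number a weaker inhibitor:
compound 1, `CCCCN1CCCN(c2nc3ccccc3n2CCOCC)CC1`, gives 8.4 nM.
compound 2, `CCCn1c(N2CCN(C)CC2)nc2ccccc21`, gives 380 nM.
compound 3, `CCOCCn1c(N2CCN(C(c3ccccc3)c3ccccc3)CC2)nc2ccccc21`, gives only a limit, > 3000 nM.

Compound 2 stands highest of the two numbers reported; the nearest, compound 1, sits well below it, a gap beyond the usual scatter. The value for compound 3 is a limit of this assay and not a number, so one of the three values shown sits at the limit of > 3000 nM in this assay, at which 1 of the 3 values shown sits.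

The step to be judged leads from compound 2 to compound 4, `COCCn1c(N2CCN(C)CC2)nc2ccccc21`. The change is methoxy in place of methyl on a saturated chain carbon, two bonds along the chain from an aromatic nitrogen. For the measured compounds named here, nothing among the measured compounds isolates this change: compound 1 and compound 3 both carry an ether chain on that nitrogen, yet they also differ from compound 2 in the amine part, and their values lie far apart. The ether chain on its own therefore gives no clear direction.

In this assay the step is expected to be small, within or near the scatter, with at most a slight move to a lower number, as a 1.5-fold lower number from compound 2 to compound 4 (0.18 log units; within the scatter) states. Compound 4 is estimated at 250 nM, with a range from 80 nM to 900 nM.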

Compound 4, half-maximal inhibitory concentration: 13 nM
Compound 4: the middle estimate sits 19-fold (1.28 log units) above what was measured, outside the stated range (below it).
By their numbers in this assay, from the lowest: compounds 1 and 4 (each within the scatter of the next); then compound 2. At a limit, above all of these: compound 3.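

In this assay, the chain on the aromatic nitrogen turns out to be a place where this one change matters: methoxy in place of methyl, on a saturated chain carbon, two bonds along the chain from an aromatic nitrogen, gives a 29-fold lower number from compound 2 to compound 4 (1.47 log units; beyond the scatter) with the amine part left as it was. For the compounds shown here, compound 1 and compound 3 also carry an ether chain, but each differs from compound 2 in the amine part as well, so only this pair isolates the exchange of propyl for 2-methoxyethyl and shows that the exchange alone can produce a large step. Nothing measured among these compounds accounts for the size of that step.

Going by these compounds, it remains open whether the oxygen has to stand where it does in the 2-methoxyethyl chain, a question that a 3-methoxypropyl or a 2-hydroxyethyl chain on the same nitrogen would address. No pair shown repeats the exchange on another amine part, so whether a step of this size carries over beyond the methylated amine of compound 2 and compound 4 also stays unsettled.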